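Swapping hydroxy for acetamido on the compound 2 side chain

A few compounds are considered here, and "the series" means these few. Any claim that something is new, unique, unknown or untested is made for them only; others in the source may bear on it.

Measured so far:
compound 1 `COc1ccc(/C=C\c2cc(OC)c(OC)c(OC)c2)cc1OCc1ccc(CN2C[C@H](O)C[C@@H]2C(=O)O)cc1`: > 10000 nM
compound 2 `COc1ccc(/C=C\c2cc(OC)c(OC)c(OC)c2)cc1OCc1ccc(CNCCO)cc1`: 4400 nM
compound 3 `COc1ccc(/C=C\c2cc(OC)c(OC)c(OC)c2)cc1OCc1ccc(CN2CCCCC2C(=O)NCCNC(=O)OC(C)(C)C)cc1`: 2000 nM

In a functional assay on HeLa cells (Homo sapiens) for antiproliferative activity, read by CCK-8 assay, with a stated time of 48 h (on this read-out higher numbers stand for weaker inhibition and lower numbers for stronger inhibition), compound 2 gives 4400 nM, the higher of the two exact numbers. Compound 3 gives the other, 2000 nM. The entry for compound 1, > 10000 nM, is a limit and not a number.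

Compound 4 `COc1ccc(/C=C\c2cc(OC)c(OC)c(OC)c2)cc1OCc1ccc(CNCCNC(C)=O)cc1` keeps the core of compound 2 and changes its side chain: acetamido in place of hydroxy on a saturated chain carbon, two bonds along the chain from an amine nitrogen. The new group is acetamido in place of hydroxy on a saturated chain carbon, two bonds along the chain from an amine nitrogen.

Within the data shown here, the one measured step, an at least 2.2-fold lower number from compound 1 to compound 2 (0.35 log units; beyond the scatter), also alters what sits on the amine nitrogen, but it starts from a limit, so its true size is unknown. It is also a different swap from this one. Compound 3, with a larger amide-bearing group on its amine nitrogen, gives 2000 nM, so nothing here suggests that such a group must raise the number.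

A small move toward a lower number is therefore expected, probably within the scatter: a 1.5-fold lower number from compound 2 to compound 4 (0.17 log units; within the scatter). For compound 4 the estimated value is 3000 nM, with an expected range of 1000 nM to 9000 nM.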

Compound 4, half-maximal inhibitory concentration: 6400 nM
Beside the measured number, compound 4's estimate is 2.1-fold (0.33 log units) below it; the measured number falls inside the stated range.
By their numbers in this assay, from the lowest: compound 3; then compounds 2 and 4 (each within the scatter of the next). At a limit, above all of these: compound 1.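

In this assay, acetamido in place of hydroxy on a saturated chain carbon, two bonds along the chain from an amine nitrogen, gives a 1.5-fold higher number from compound 2 to compound 4 (0.16 log units; within the scatter). Among these compounds, this is the first direct reading of a change at this chain end, and it shows that replacing the hydroxy with the bigger acetamido group leaves the number within the scatter, so this one swap shows no clear effect in either direction. The other new step, an at least 1.5-fold lower number from compound 1 to compound 4 (0.19 log units; that floor lies within the scatter), starts from a limit, so its true size cannot be read: the limit of > 10000 nM in this assay, at which 1 of the 4 values shown sits.

The compounds shown leave open whether any group at this chain end can move the number beyond the scatter. A primary amine or a carboxylic acid in place of acetamido, or a longer chain carrying the acetamido group, would test this.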